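This account rests on a few compounds, and the source may have more. Where it says the series, first, only, none or still open, it means among the compounds named here.

Series notes. Compound 1 `COc1ccc(-c2cc(C(=O)Nc3nc4ccc(Cl)cc4s3)nc3cc(-c4ccccc4)nn23)cc1OC` is the reference point; in a functional assay on ACHN cells (Homo sapiens) for cytotoxicity, read by MTT assay, with a stated time of 48 h (on this read-out lower numbers stand for stronger inhibition and higher numbers for weaker inhibition), compound 1 gives 7760 nM. Compound 2 `COc1cc(-c2cc(C(=O)Nc3nc4ccc(Cl)cc4s3)nc3cc(-c4ccccc4)nn23)cc(OC)c1OC` differs from compound 1 in one place: methoxy in place of hydrogen on an aromatic carbon In this assay compound 2 gives 41700 nM, so the step was a 5.4-fold higher number from compound 1 to compound 2 (0.73 log units; beyond the scatter).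

Compound 3 `COc1ccc(-c2cc(C(=O)Nc3nc4cc(C)c(C)cc4s3)nc3cc(-c4ccccc4)nn23)cc1` carries another core; the difference between the core of compound 1 and the core of compound 3 is not broken down here. In this assay compound 3 gives 22400 nM, a number within the scatter of the value of compound 2 and beyond the scatter of the value of compound 1.

Compound 4 `COc1ccc(-c2cc(C(=O)Nc3nc4cc(C)c(C)cc4s3)nc3cc(-c4ccccc4)nn23)cc1OC` has not been measured. It differs from compound 3 in one place: methoxy in place of hydrogen on an aromatic carbon This is the same kind of change as the one from compound 1 to compound 2, which occurs twice among these compounds, but not the same change: in compound 1 the entering group sits ortho to a methoxy group, meta to a large group and also meta to a methoxy group, whereas in compound 3 it sits ortho to a methoxy group and meta to a large group only, and the cores differ. For the measured compounds named here, the one measured example of this kind of change, a 5.4-fold higher number from compound 1 to compound 2 (0.73 log units; beyond the scatter), gave a modest weakening; with a different core and surroundings no more than a small step is expected, and its direction is uncertain. The step from compound 3 to compound 4 is estimated as a 1.1-fold higher number from compound 3 to compound 4 (0.05 log units; within the scatter). In this assay compound 4 is expected at 25000 nM, with an estimated range from 8000 nM to 80000 nM.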

Compound 4, half-maximal inhibitory concentration: 8700 nM
Compound 4: the middle estimate sits 2.9-fold (0.46 log units) above what was measured; the measured number falls inside the stated range.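

In this assay, methoxy in place of hydrogen, turning the 4-methoxyphenyl of compound 3 into the 3,4-dimethoxyphenyl of compound 4, gives a 2.6-fold lower number from compound 3 to compound 4 (0.41 log units; beyond the scatter), so this change does not carry its direction or size from one core to the other in this series: the same change on two cores in this assay, a 5.4-fold higher number (0.73 log units; beyond the scatter) from compound 1 to compound 2 and a 2.6-fold lower number (0.41 log units; beyond the scatter) from compound 3 to compound 4, 14-fold (1.14 log units) apart, beyond the scatter of two such steps

With the 3,4-dimethoxyphenyl group held fixed, 5,6-dimethyl-1,3-benzothiazol-2-yl in place of 6-chloro-1,3-benzothiazol-2-yl gives a 1.1-fold higher number from compound 1 to compound 4 (0.05 log units; within the scatter), so the two cores cannot be told apart when they carry that group, and their difference appears only with the other aromatic substituents. What this does not show is whether the core alone accounts for the opposite steps, since the two examples also differ in the groups already on the aromatic ring, and each rests on a single pair of compounds.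

Still open, on these data alone, is how a 4-methoxyphenyl group behaves on the core of compound 1 and how a further methoxy behaves on compound 4, the two compounds that would allow each step to be compared with the same starting substitution on both cores. Also open, as far as these compounds go, is whether a hydroxy group, an amine or a carboxylic acid at the same aromatic carbon would follow either methoxy step.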